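From thiophen-2-yl to cyclohexyl on the carbonyl carbon

This account rests on a few compounds, and the source may have more. Where it says the series, first, only, none or still open, it means among the compounds named here.

Measured so far in an ADME assay on U2OS cells (Homo sapiens) for cytotoxicity; a higher number here means that more compound is tolerated, a lower number that less compound is tolerated:
- compound 1 `CC(C)(C)c1ccc(C(=O)N/N=C/c2ccc([N+](=O)[O-])o2)cc1`: > 200000 nM (a limit)
- compound 2 `O=C(N/N=C/c1ccc([N+](=O)[O-])o1)c1cccs1`: 57200 nM
- compound 3 `CCCCc1ccc(C(=O)N/N=C/c2ccc([N+](=O)[O-])o2)cc1`: 19600 nM

Compound 2 at 57200 nM has the higher of the two actual numbers, and compound 3 at 19600 nM lies beyond the scatter from it. The entry for compound 1, > 200000 nM, is a limit and not a number.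

Compound 4 `O=C(N/N=C/c1ccc([N+](=O)[O-])o1)C1CCCCC1` carries cyclohexyl in place of thiophen-2-yl on a carbonyl carbon.

Among the measured compounds shown here, only one measured step is available, an at least 10-fold lower number from compound 1 to compound 3 (1.00 log units; beyond the scatter). It exchanges butyl for tert-butyl on an aromatic carbon, so it does not test the carbonyl-side group directly. Its size rests on (the limit of > 200000 nM in this assay, at which 1 of the 3 values shown sits). With compound 3 so far from compound 1 in this assay, a wide range is kept, but no direction can be drawn from that step. The expected change is a 1.1-fold lower number from compound 2 to compound 4 (0.06 log units; within the scatter), and this is no step beyond the scatter. For compound 4 the estimated value is 50000 nM, with an expected range of 15000 nM to 160000 nM.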

Compound 4, half-maximal cytotoxic concentration: 25400 nM
The estimate for compound 4 lay 2.0-fold (0.29 log units) above the measured number; measured number inside the range.
By their numbers in this assay, from the lowest: compounds 3 and 4 (each within the scatter of the next); then compound 2. At a limit, above all of these: compound 1.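

In this assay the group on the carbonyl carbon gets its first direct test, and cyclohexyl in place of thiophen-2-yl gives a 2.3-fold lower number from compound 2 to compound 4 (0.35 log units; beyond the scatter) as a modest step. Among the compounds shown here, the only earlier step changed a group on an aromatic carbon, so this is the first sign that the carbonyl-side group also moves the tolerated concentration. The swap replaces a five-membered aromatic ring holding sulfur with a six-membered non-aromatic ring of carbon only, and nothing shown separates these differences or gives a reason for the step.

From the compounds shown here alone, it remains open whether unsubstituted phenyl or cyclopentyl on the carbonyl carbon would stand closer to compound 2 or to compound 4. Also open, going by these compounds, is how a ring carrying an amine, such as piperidin-4-yl, would behave at this position.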